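A few compounds are considered here, and "the series" means these few. Any claim that something is new, unique, unknown or untested is made for them only; others in the source may bear on it.

Three compounds have a reading so far in a functional assay on A549 cells (Homo sapiens) for antiproliferative activity, read by MTT assay, with a stated time of 24 h; a lower number here means a stronger inhibitor, a higher number a weaker inhibitor. Compound 1 (`FC(F)(F)c1ccc(-c2nn(-c3ccccc3)cc2-c2nc3ccccc3[nH]2)cc1`) gives 3620 nM as its value. Compound 3 (`O=S(=O)(c1ccc(F)cc1)n1c(-c2cn(-c3ccccc3)nc2-c2ccc(C(F)(F)F)cc2)nc2ccccc21`) gives 1740 nM as its value. Among the measured compounds shown here, putting (4-fluorophenyl)sulfonyl in place of hydrogen on an aromatic nitrogen accounts for a 2.1-fold lower number from compound 1 to compound 3 (0.32 log units; beyond the scatter) and this modest move is the only single-place step measured. Compound 2 (`Cc1ccc(-c2nn(-c3ccccc3)cc2-c2nc3ccccc3n2S(=O)(=O)c2ccc(Br)cc2)cc1`) gives 1860 nM as its value, within the scatter of compound 3, so these two share the low end of the set.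

The next structure is compound 4 (`O=S(=O)(c1ccc(Br)cc1)n1c(-c2cn(-c3ccccc3)nc2-c2ccc(C(F)(F)F)cc2)nc2ccccc21`), and its difference from compound 3 is bromo in place of fluoro on an aromatic carbon in all. In words, this is bromo in place of fluoro on an aromatic carbon, para to a large group, which turns (4-fluorophenyl)sulfonyl into (4-bromophenyl)sulfonyl. For the measured compounds named here, no measured step isolates this exchange. The step to compound 3 concerns the sulfonyl group as a whole, not the halogen on it. The nearest evidence is compound 2, which also carries (4-bromophenyl)sulfonyl and reads 1860 nM in the same range as compound 3. No shift beyond the scatter is therefore expected in this assay for this exchange. The estimated change is a 1.0-fold higher number from compound 3 to compound 4 (0.01 log units; within the scatter) and no clear direction is expected. Compound 4 is estimated at 1800 nM with an expected range of 950 nM to 3400 nM for its value.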

Compound 4, half-maximal inhibitory concentration: 1690 nM
Compound 4: middle estimate off by 1.1-fold (0.03 log units), on the high side, and the stated range covers the measured number.
By their numbers in this assay, from the lowest: compounds 4, 3, 2 and 1 (each within the scatter of the next, the first and the last beyond it).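

In this assay, the exchange of fluoro for bromo on the aromatic carbon para to a large group now has a direct reading, a 1.0-fold lower number from compound 3 to compound 4 (0.01 log units; within the scatter), so the two halogens cannot be told apart at this position of the (4-halophenyl)sulfonyl group. With (4-bromophenyl)sulfonyl held constant, trifluoromethyl in place of methyl on an aromatic carbon gives a 1.1-fold lower number from compound 2 to compound 4 (0.04 log units; within the scatter), so that exchange also stays within the scatter. Placing (4-bromophenyl)sulfonyl on the aromatic nitrogen gives a 2.1-fold lower number from compound 1 to compound 4 (0.33 log units; beyond the scatter), which is close in size to a 2.1-fold lower number from compound 1 to compound 3 (0.32 log units; beyond the scatter), so the modest step from the unsubstituted nitrogen appears with either halogen.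

No measurement available here accounts for these readings. The compounds shown leave open whether a group of another kind on this aromatic carbon, such as an amine, a methoxy group or a carboxylic acid, would move the number beyond the scatter, and whether an acetyl or benzoyl group on the aromatic nitrogen would give a step like that of the two arylsulfonyl groups.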